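This account rests on a few compounds, and the source may have more. Where it says the series, first, only, none or still open, it means among the compounds named here.

Measured so far in an ADME assay on MT2 cells (Homo sapiens) for cytotoxicity, read by MTT assay; on this read-out lower numbers stand for higher toxicity in this test and higher numbers for lower toxicity in this test:
- compound 1 `N#Cc1cc2c(Oc3ccccc3OCCn3ccc(=O)[nH]c3=O)cc(Cl)cc2o1`, > 100000 nM
- compound 2 `Cc1ccc2c(Oc3ccccc3OCCn3ccc(=O)[nH]c3=O)cccc2c1`, 40000 nM
- compound 3 `N#Cc1ccc2c(Oc3ccc(Cl)cc3OCCn3ccc(=O)[nH]c3=O)cc(Cl)cc2c1`, 20000 nM

Compound 1 gives no number in this assay, only a limit, > 100000 nM; it sits at the limit of > 100000 nM in this assay, at which 1 of the 3 values shown sits. Compound 2 gives a number, 40000 nM. Compound 3 also gives a number, 20000 nM. Both of these numbers lie on the side of higher toxicity relative to where compound 1 stands. Among the compounds with values here, no two of the three measured compounds differ in one place, so no single measured step is available.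

Compound 4 `N#Cc1cc2c(Oc3ccccc3OCCn3ccc(=O)[nH]c3=O)cccc2o1` is the unmeasured member. It differs from compound 1 as follows: hydrogen in place of chloro on an aromatic carbon.

In this assay the step from compound 1 to compound 4 is expected to be small, with no clear direction beyond the scatter, since compound 1 itself only reaches the limit > 100000 nM and nothing in the shown numbers ties the chloro to the read-out. The expected step is a number no higher from compound 1 to compound 4 (the limit leaves the size open). Compound 4 is estimated at 100000 nM, with a range from 40000 nM to 250000 nM, and there is a fair chance this assay will again return only a limit for compound 4 rather than a number.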

Compound 4, half-maximal cytotoxic concentration: > 100000 nM
Compound 4 gave a limit, no number; the forecaster's own chance of this, stated with the estimate: 60%; the middle value lies on the limit itself.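

Compound 1 and compound 4 both return only a limit in this assay, so the step of hydrogen in place of chloro on an aromatic carbon cannot be read: the limit of > 100000 nM in this assay, at which 2 of the 4 values shown sit.

The compounds shown leave open whether this exchange changes the read-out at all, and how far past the limit either compound lies.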